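From cyclobutylmethyl to 1-methylbutyl on the aromatic nitrogen

A few compounds are considered here, and "the series" means these few. Any claim that something is new, unique, unknown or untested is made for them only; others in the source may bear on it.

Measured in an in vitro ADME assay on microsomes from liver (Homo sapiens) for metabolic stability, tested at 5 uM; on this read-out higher numbers stand for a longer-lived compound and lower numbers for a shorter-lived compound:
Compound 1 `CCC(C)(C)Cn1nc(-c2cccs2)c(O)c(C2=NS(=O)(=O)c3cc(NS(C)(=O)=O)ccc3N2)c1=O`: > 1 h (a limit)
Compound 2 `CS(=O)(=O)Nc1ccc2c(c1)S(=O)(=O)N=C(c1c(O)c(-c3cccs3)nn(CC3CCC3)c1=O)N2`: > 1 h (a limit)

Compound 2 stands only at a limit, > 1 h, and so has no exact half-life. Both measured compounds share one reading: the limit of > 1 h in this assay, at which 2 of the 2 values shown sit. Compound 3 `CCCC(C)n1nc(-c2cccs2)c(O)c(C2=NS(=O)(=O)c3cc(NS(C)(=O)=O)ccc3N2)c1=O` carries 1-methylbutyl in place of cyclobutylmethyl on an aromatic nitrogen. Among the measured compounds shown here, only one measured step bears on this change. That step, a step that the two limits leave unreadable from compound 1 to compound 2, places cyclobutyl in place of 1,1-dimethylpropyl on a saturated chain carbon bound to an aromatic nitrogen. It offers no size to carry over, so no step beyond the scatter is expected in this assay, and another limit is the likely report. The estimated change is a step that the limit leaves unreadable from compound 2 to compound 3. For compound 3 the expected half-life is 1.5 h, with an estimated range of 1 h to 3 h.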

Compound 3, half-life: > 1 h
Compound 3 was reported as a limit; the forecaster's own chance of this, stated with the estimate: 85%; the middle value lies beyond the limit too.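

Among the compounds shown here, compound 1, compound 2 and compound 3 cannot be told apart in this assay, and no step among them can be read: the limit of > 1 h in this assay, at which 3 of the 3 values shown sit. The compounds shown leave open what the actual half-life of each is, and whether the groups on the aromatic nitrogen differ at all.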